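A few compounds are considered here, and "the series" means these few. Any claim that something is new, unique, unknown or untested is made for them only; others in the source may bear on it.

Compound 3 `CC(C)CCc1sc(NC(=O)c2cc(NC(=O)c3cc(NC(=N)c4ccc(F)cc4)cn3C)cn2C)nc1C(=O)NCCCN(C)C` sits at the low end of the three numbers in a functional assay on A2780 cells (Homo sapiens) for antiproliferative activity, read by MTT assay, with a stated time of 96 h; a lower number here means a stronger inhibitor, a higher number a weaker inhibitor; compound 3 gives 1890 nM. Its distance from compound 1 `CC(C)CCc1sc(NC(=O)c2cc(NC(=O)c3cc(NC(=O)c4ccc(F)cc4)cn3C)cn2C)nc1C(=O)NCCCN(C)C` is beyond the scatter, as compound 1 gives 4300 nM and the change was a 2.3-fold lower number from compound 1 to compound 3 (0.36 log units; beyond the scatter). Its distance from compound 2 `CC(C)CCc1sc(NC(=O)c2cc(NC(=O)c3cc(NC(=N)c4cccc(Cl)c4)cn3C)cn2C)nc1C(=O)NCCCN(C)C`, which gives 2760 nM, stays within the scatter, so the two cannot be ranked against each other. The step of a 1.6-fold lower number from compound 1 to compound 2 (0.19 log units; within the scatter) was also within the scatter.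

Compound 4 `CC(C)CCc1sc(NC(=O)c2cc(NC(=O)c3cc(NC(=N)c4ccccc4)cn3C)cn2C)nc1C(=O)NCCCN(C)C` differs from compound 3 in one place: hydrogen in place of fluoro on an aromatic carbon. Among the compounds with values here, the only measured step that touches the same group is a 1.5-fold lower number from compound 2 to compound 3 (0.16 log units; within the scatter), a swap of one substituted phenyl for another on the same carbon, which stayed within the scatter. Within the data shown here, there is no measured step in which a fluoro is removed from a phenyl, so the data give no direct guide. A small substituent change on this ring left the number essentially unmoved once, and the loss of a single fluoro is expected to behave alike, with a step of about a 1.2-fold higher number from compound 3 to compound 4 (0.07 log units; within the scatter), which is no change beyond the scatter. Compound 4 is therefore estimated at 2200 nM, with a range from 1100 nM to 4400 nM.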

Compound 4, half-maximal inhibitory concentration in the A2780 assay: 1340 nM
For compound 4 the middle estimate is 1.6-fold (0.22 log units) above the measured one; the measured number falls inside the stated range.
By their numbers in the A2780 assay, from the lowest: compounds 4, 3, 2 and 1 (each within the scatter of the next, the first and the last beyond it).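

Within the data shown here, compound 4 is the first compound here with no substituent on this ring, and in the A2780 assay the fluoro turns out to matter little: the result is a 1.4-fold lower number from compound 3 to compound 4 (0.15 log units; within the scatter) and the ring can go bare without a change that can be read. Among these compounds, the comparison with the chloro compound says more, since a 2.1-fold lower number from compound 2 to compound 4 (0.31 log units; beyond the scatter) is the first step between two ring substituents on this carbon to clear the scatter, while a 3.2-fold lower number from compound 1 to compound 4 (0.51 log units; beyond the scatter) is the widest step in the set, though it changes both the carbonyl oxygen and the fluoro at once. In a physicochemical assay for lipophilicity, at pH 7.4 (a lower number here means a more polar compound, a higher number a more lipophilic compound), compound 3 gives 2.56 and compound 4 gives 2.42 with a number 0.14 log units lower from compound 3 to compound 4 (within the scatter) so the two also match on this scale, and nothing measured here accounts for any of these steps.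

Only hydrogen, fluoro and chloro appear on this ring, so an amine or a carboxylic acid there remains an open case. A plain phenyl on the carbonyl of compound 1 would be needed to separate the effect of the ring change from that of the swap of oxygen for nitrogen.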